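A few compounds are considered here, and "the series" means these few. Any claim that something is new, unique, unknown or untested is made for them only; others in the source may bear on it.

Compounds measured so far:
compound 1 `C=C[C@@](C)(/C=C/c1ccc(OC)cc1)CCC=C(C)C` — > 49000 nM
compound 2 `C=C[C@@](C)(/C=C/c1ccc(O)c(/C=C/C(=O)c2ccccc2)c1)CCC=C(C)C` — > 49000 nM

In a functional assay on Jurkat cells (Homo sapiens) for cytotoxicity, with a stated time of 72 h (a higher number here means that more compound is needed for the effect, a lower number that less compound is needed), compound 1 gives > 49000 nM, which is a limit of the assay and not a number. Compound 2 gives > 49000 nM in this assay, again a limit rather than a measured value. Among the compounds with values here, compound 2 therefore stands where every value shown stands, at the limit of > 49000 nM in this assay, at which 2 of the 2 values shown sit; no measured compound sets it apart from compound 1, and no step between measured compounds is available.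

Compound 3 `C=C[C@@](C)(/C=C/c1ccc(O)c(/C=C/c2ccc(Cl)cc2)c1)CCC=C(C)C` differs from compound 2 in one place: 4-chlorophenyl in place of benzoyl on a double-bonded chain carbon bound to a double-bonded chain carbon. With both measured compounds at the limit, there is no basis for expecting a step beyond the usual scatter in this assay in either direction. Compound 3 is expected to come out around 60000 nM, with a range from 20000 nM to 200000 nM. This estimate corresponds to a step that the limit leaves unreadable from compound 2 to compound 3, expected to stay within the scatter.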

Compound 3, half-maximal effective concentration: > 49000 nM
Compound 3 was reported as a limit; the forecaster's own chance of this, stated with the estimate: 80%; the middle value lies beyond the limit too.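

Within the data shown here, compound 3, like compound 2, sits at a limit of the assay rather than at a number in this assay, so no step between them can be read: the limit of > 49000 nM in this assay, at which 3 of the 3 values shown sit. The compounds shown leave open whether any change to the shared core would give a measured value in this assay.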